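Compound 4: cyclopropyl on an amide-type nitrogen

The source may report more compounds than this note shows. Statements on the series, on what has been measured and on what is new or still open speak of the compounds shown alone.

Measured in a physicochemical assay for solubility; a lower number here means a less soluble compound, a higher number a more soluble compound:
- Compound 1 `CCCNC(=O)c1cc(C(=O)NC)nn1[C@@H](C)c1ccccc1`: >= 132 ug/mL
- Compound 2 `CNC(=O)c1cc(C(=O)N[C@H]2CC[C@H](O)CC2)n([C@@H](C)c2ccccc2)n1`: >= 180 ug/mL
- Compound 3 `CNC(=O)c1cc(C(=O)NC(C)CO)n([C@@H](C)c2ccccc2)n1`: >= 132 ug/mL

All three values are limits of the assay, not numbers. Compound 3 therefore stands at a limit, >= 132 ug/mL, and its true value is not known.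

Compound 4 `CNC(=O)c1cc(C(=O)NC2CC2)n([C@@H](C)c2ccccc2)n1` has cyclopropyl in place of 1-(hydroxymethyl)ethyl on an amide-type nitrogen.

The measured steps change the group at this same place. They are a step that the two limits leave unreadable from compound 1 to compound 2, a step that the two limits leave unreadable from compound 1 to compound 3 and a step that the two limits leave unreadable from compound 2 to compound 3. The values sit at only two limits: the limit of >= 132 ug/mL in this assay, at which 2 of the 3 values shown sit, and (the limit of >= 180 ug/mL in this assay, at which 1 of the 3 values shown sits). Compound 1, with propyl on that nitrogen, also gives a limit, >= 132 ug/mL.

With no readable step size to carry over, no direction can be expected, and the expected change is a step that the limit leaves unreadable from compound 3 to compound 4, none beyond the usual scatter. A further limit in this assay would not be surprising. For compound 4 the estimated value is 140 ug/mL, with an expected range from 70 ug/mL to 200 ug/mL.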

Compound 4, solubility: >= 165 ug/mL
Compound 4: no number, only a limit; the forecaster's own chance of this, stated with the estimate: 65%; middle value at least 1.1-fold (0.07 log units) away from the limit.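

In this assay compound 4 gives >= 165 ug/mL, a limit of the assay and not a number. Its steps from compound 1, compound 2 and compound 3 cannot be read. The compounds shown leave open whether changing the group on the amide-type nitrogen shifts solubility at all.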